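This account rests on a few compounds, and the source may have more. Where it says the series, first, only, none or still open, it means among the compounds named here.

The compounds here share one core and differ only in the group carried on a nitrogen on an aromatic ring. Compound 1 `FC(F)(F)c1ccc(CSc2nc(Nc3ccccc3C(F)(F)F)c3ccccc3n2)cc1` carries a 2-(trifluoromethyl)phenyl there. In a functional assay on MCF7 cells (Homo sapiens) for cytotoxicity, read by MTT assay, with a stated time of 72 h (a lower number here means a stronger inhibitor, a higher number a weaker inhibitor), compound 1 gives only a limit, > 50000 nM, and no number. Compound 2 `FC(F)(F)c1ccc(CSc2nc(Nc3ccc(Cl)cc3)c3ccccc3n2)cc1` carries a 4-chlorophenyl instead, and in this assay compound 2 gives 21500 nM, the only number shown among these compounds. Of the two values shown, one sits at a limit (the limit of > 50000 nM in this assay, at which 1 of the 2 values shown sits). Among the measured compounds shown here, the step between the two measured compounds, an at least 2.3-fold lower number from compound 1 to compound 2 (0.36 log units; beyond the scatter), is the only measured step available.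

Compound 3 `O=[N+]([O-])c1ccc(Nc2nc(SCc3ccc(C(F)(F)F)cc3)nc3ccccc23)cc1` arises from compound 2 by a further swap: nitro in place of chloro on an aromatic carbon. For the measured compounds named here, no measured step touches this exchange, and the one measured step concerns a different change on that ring, so it gives little guidance about size or direction here. A change within the scatter, or a modest one either way, is the expectation. Compound 3 is therefore expected to come out near 15000 nM, within 5000 nM to 50000 nM. The expected step of a 1.4-fold lower number from compound 2 to compound 3 (0.16 log units; within the scatter) is small.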

Compound 3, half-maximal inhibitory concentration: 17900 nM
For compound 3 the middle estimate is 1.2-fold (0.08 log units) below the measured one; low and high end bracket the measured number.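

In this assay, replacing chloro with nitro on this aromatic carbon, para to a large group, gives a 1.2-fold lower number from compound 2 to compound 3 (0.08 log units; within the scatter), so a single chlorine and a group of 3 heavy atoms with 2 hydrogen-bond acceptors cannot be told apart at this place. Replacing 2-(trifluoromethyl)phenyl with 4-nitrophenyl on the nitrogen gives an at least 2.7-fold lower number from compound 1 to compound 3 (0.44 log units; beyond the scatter), so a second group, after 4-chlorophenyl, now yields a measured number where the 2-(trifluoromethyl)phenyl compound yields none. Compound 1 gives only a limit, so both steps that start from it are bounds and not exact sizes: the limit of > 50000 nM in this assay, at which 1 of the 3 values shown sits.

Going by these compounds, it remains open whether an amine or a carboxylic acid on this same aromatic carbon would leave the number as little changed as nitro does. On these data alone, it is also open how much of the steps from compound 1 comes from the identity of the group and how much from where it sits on the ring, as the 2-(trifluoromethyl)phenyl group differs from the other two in both respects; a 4-(trifluoromethyl)phenyl group on that nitrogen would separate the two.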